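A Step from 4-Chlorophenyl to 2-Bromophenyl

This account rests on a few compounds, and the source may have more. Where it says the series, first, only, none or still open, it means among the compounds named here.

In a functional assay on A2780 cells (Homo sapiens) for cytotoxicity, read by MTT assay, with a stated time of 68 h (on this read-out higher numbers stand for weaker inhibition and lower numbers for stronger inhibition), three compounds sharing one core have been measured. Compound 1 (`O=C(/C=C/c1cccc(OCc2ccccc2)c1)c1ccc([N+](=O)[O-])cc1`) gives 56400 nM, and compound 2 (`O=C(/C=C/c1cccc(OCc2ccccc2)c1)c1ccc(O)cc1`) gives 1000 nM. Compound 3 (`O=C(/C=C/c1cccc(OCc2ccccc2)c1)c1ccc(Cl)cc1`) gives 56400 nM, level with compound 1 at the digits shown, and together these two hold the highest number of the three. Chloro in place of nitro gives no change at the digits printed from compound 1 to compound 3 (within the scatter). Hydroxy in place of nitro gives a 56-fold lower number from compound 1 to compound 2 (1.75 log units; beyond the scatter), and chloro in place of hydroxy gives a 56-fold higher number from compound 2 to compound 3 (1.75 log units; beyond the scatter).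

The next step leads to compound 4 (`O=C(/C=C/c1cccc(OCc2ccccc2)c1)c1ccccc1Br`), with 2-bromophenyl in place of 4-chlorophenyl on a carbonyl carbon. Going by the values given here, no measured step covers a bromo group or this change of ring substitution, so the evidence is indirect. The two large steps both involve the hydroxy group of compound 2, which compound 4 lacks. The nearest guide is the non-hydroxy pair, which shows no change at the digits printed from compound 1 to compound 3 (within the scatter). A step within the scatter is therefore expected, with any real shift more likely towards a lower number. The expected step is a 1.4-fold lower number from compound 3 to compound 4 (0.15 log units; within the scatter). For compound 4 the estimated value is 40000 nM, with an expected range from 8000 nM to 90000 nM.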

Compound 4, half-maximal inhibitory concentration: 2500 nM
Compound 4: middle estimate off by 16-fold (1.20 log units), on the high side, outside the stated range (below it).
By their numbers in this assay, from the lowest: compound 2; then compound 4; then compounds 1 and 3 (each within the scatter of the next).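

In this assay, the group on this carbonyl carbon can shift the number strongly without any hydroxy group, which the earlier compounds had not shown: the step of a 23-fold lower number from compound 3 to compound 4 (1.35 log units; beyond the scatter) comes with 2-bromophenyl in place of 4-chlorophenyl, and the step of a 23-fold lower number from compound 1 to compound 4 (1.35 log units; beyond the scatter) comes with 2-bromophenyl in place of 4-nitrophenyl. Compound 2 still holds the lowest number of the four, since the step of a 2.5-fold higher number from compound 2 to compound 4 (0.40 log units; beyond the scatter) with 2-bromophenyl in place of 4-hydroxyphenyl is modest but beyond the scatter. Nothing measured here gives a reason for these differences.

The change from compound 3 to compound 4 replaces the chlorine with a bromine and also alters the substitution of the ring, so the compounds shown leave open which of these two differences accounts for the step. On these data alone, how an amine or a carboxylic acid on this aromatic ring would read in this assay also remains open, as does whether the large gap from compounds 1 and 3 would hold for other halogens.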